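The compounds below may be only part of what the source reports. "The series", "measured", "known", "first", "only" and "open" are said of these compounds alone.

Of the compounds shown here, three on the shared core have numbers so far. In a functional assay on EBC-1 cells (Homo sapiens) for antiproliferative activity, with a stated time of 72 h (a higher number here means a weaker inhibitor, a lower number a stronger inhibitor), compound 1 (`N#Cc1ccc(-c2cc(F)c3ncc(Cc4ccc5ncccc5c4)n3c2)cn1`) gives 189 nM and compound 2 (`N#Cc1ccc(-c2cc(F)c3ncc(Cc4ccc5ncccc5c4)n3c2)cc1F`) gives 145 nM with a gap of a 1.3-fold lower number from compound 1 to compound 2 (0.12 log units; within the scatter) that does not separate them. Compound 3 (`CN1CCN(C(=O)c2ccc(-c3cc(F)c4ncc(Cc5ccc6ncccc6c5)n4c3)cc2F)CC1`) gives 869 nM as the highest number of the three, beyond the scatter from both others.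

Compound 4 (`O=C(NCc1ccccn1)c1ccc(-c2cc(F)c3ncc(Cc4ccc5ncccc5c4)n3c2)cc1F`) carries ((pyridin-2-yl)methyl)amino in place of 4-methylpiperazin-1-yl on a carbonyl carbon. For the measured compounds named here, no measured step varies the group on this carbonyl, so the evidence is indirect. The nearest step is a 6.0-fold higher number from compound 2 to compound 3 (0.78 log units; beyond the scatter) on placing (4-methylpiperazin-1-yl)carbonyl where cyano stood. Going by the values given here, it shows only that this one carbonyl-linked group gives a higher number than the nitrile of compound 2. The step of a 1.3-fold lower number from compound 1 to compound 2 (0.12 log units; within the scatter) concerns another part of the molecule and says little here.

Compound 4 keeps a carbonyl at that place, so a full return to the level of compound 2 is not expected. A small move toward a lower number is expected, and it may not clear the scatter. The estimated change is a 1.7-fold lower number from compound 3 to compound 4 (0.24 log units; within the scatter) in this assay on this reasoning. For compound 4 the expected value is 500 nM with an estimated range of 170 nM to 1300 nM in this assay as the read-out.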

Compound 4, half-maximal inhibitory concentration: 5550 nM
For compound 4 the middle estimate is 11-fold (1.05 log units) below the measured one; the measured number lies above the stated range.
By their numbers in this assay, from the lowest: compounds 2 and 1 (each within the scatter of the next); then compound 3; then compound 4.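

In this assay, the group on the carbonyl carbon matters in its own right: placing ((pyridin-2-yl)methyl)amino where 4-methylpiperazin-1-yl stood gives a 6.4-fold higher number from compound 3 to compound 4 (0.81 log units; beyond the scatter), so keeping the carbonyl does not fix the level at this place. Against the nitrile, ((pyridin-2-yl)methyl)carbamoyl gives a 38-fold higher number from compound 2 to compound 4 (1.58 log units; beyond the scatter), while (4-methylpiperazin-1-yl)carbonyl gives a 6.0-fold higher number from compound 2 to compound 3 (0.78 log units; beyond the scatter), so both carbonyl-linked groups shown have higher numbers than the nitrile of compound 2, and the size of the penalty depends on the group carried by the carbonyl. No measurement is available that accounts for the difference between these two groups.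

The compounds shown do not separate the contribution of the amide hydrogen from that of the pyridine ring, and a benzylamide, with a phenyl ring in place of the pyridine, or a simple methylamide would bear on that question. Also open, going by these compounds, is whether a primary amide or a carboxylic acid at this place would fall nearer compound 2 or compound 4 in this assay.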